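Swapping the benzyl substituent on a nitrothiazole amide

This account rests on a few compounds, and the source may have more. Where it says the series, first, only, none or still open, it means among the compounds named here.

Measured in an assay on isolated protein for inhibition of ubiquitin carboxyl-terminal hydrolase 7 (Homo sapiens), read by fluorescence, with stated times of 30 min and 3 h; a higher number here means a weaker inhibitor, a lower number a stronger inhibitor:
Compound 1 `COc1cccc(Sc2sc(C(C)=O)nc2[N+](=O)[O-])c1` gives > 50000 nM, a limit of this assay.
Compound 2 `O=C(NCc1cccc(F)c1)c1nc([N+](=O)[O-])c(Sc2c(Cl)cncc2Cl)s1` gives 1350 nM.
Compound 3 `CC(NCc1ccccc1)c1nc([N+](=O)[O-])c(Sc2c(Cl)cncc2Cl)s1` gives 26800 nM.

Of the two numbers shown, compound 2 has the lower; compound 3 stands higher, beyond the scatter. For compound 1 only the limit of > 50000 nM in this assay, at which 1 of the 3 values shown sits, is known.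

Compound 4 `Cc1ccc(CNC(=O)c2nc([N+](=O)[O-])c(Sc3c(Cl)cncc3Cl)s2)cc1` keeps the amide and the rest of the shared core and differs from compound 2 only by 4-methylphenyl in place of 3-fluorophenyl on a saturated chain carbon bound to an amide-type nitrogen. Going by the values given here, no pair of measured compounds tests this change directly, so the expectation rests on compound 2 alone: the step of a 1.2-fold higher number from compound 2 to compound 4 (0.07 log units; within the scatter) is expected to stay within the scatter. Compound 4 is therefore estimated at 1600 nM, between 500 nM and 5000 nM.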

Compound 4, half-maximal inhibitory concentration: 3650 nM
Beside the measured number, compound 4's estimate is 2.3-fold (0.36 log units) below it, and the stated range covers the measured number.
By their numbers in this assay, from the lowest: compound 2; then compound 4; then compound 3. At a limit, above all of these: compound 1.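

In this assay, the position on the saturated chain carbon bound to an amide-type nitrogen responds to a single substituent swap: 4-methylphenyl in place of 3-fluorophenyl gives a 2.7-fold higher number from compound 2 to compound 4 (0.43 log units; beyond the scatter). This is the only one-place step among the compounds shown, and it is modest. Nothing measured here accounts for it. The two groups differ in both substituent and ring position, so the step cannot be assigned to either difference. As far as these compounds go, how 3-methylphenyl or 4-fluorophenyl would read at this position remains open.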